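Removing the (ethylsulfonyl)amino group from compound 2

This account rests on a few compounds, and the source may have more. Where it says the series, first, only, none or still open, it means among the compounds named here.

Three compounds have been run so far in a functional assay on CHO cells for agonist activity at Alpha-1D adrenergic receptor (Homo sapiens), read by FLIPR and calcium flux (a higher number here means that more compound is needed for the effect, a lower number that less compound is needed), and each sits at the assay limit rather than at a number. Compound 1 `Cc1c(OCC2=NCCN2)ccc(Cl)c1NS(C)(=O)=O` gives > 10000 nM in this assay, which is a limit. Compound 2 `CCS(=O)(=O)Nc1cccc2c1CCC2c1ncc[nH]1` gives > 10000 nM in this assay, again a limit. Compound 3 `Clc1ccc2c(c1-c1ccn[nH]1)CCC2c1ncc[nH]1` gives > 10000 nM in this assay, a limit as well. For the measured compounds named here, compound 2 therefore stands where every other value shown stands, at the limit of > 10000 nM in this assay, at which 3 of the 3 values shown sit, and no step between measured compounds can be drawn from these data.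

Compound 4 `c1ccc2c(c1)CCC2c1ncc[nH]1` differs from compound 2 in one place: hydrogen in place of (ethylsulfonyl)amino on an aromatic carbon. Going by the values given here, with no measured step available and no compound in the set yet giving a number, there is nothing to suggest that this change moves the read-out past the scatter in this assay; the expectation is no step beyond the scatter. Compound 4 is expected to give about 15000 nM, with a range of 4000 nM to 60000 nM, and most likely to be reported only as a limit. The step estimated here is a step that the limit leaves unreadable from compound 2 to compound 4.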

Compound 4, half-maximal effective concentration: > 10000 nM
Compound 4 ended at the assay's limit; the forecaster's own chance of this, stated with the estimate: 80%; the middle value lies beyond the limit too.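

No step can be read between compound 2 and compound 4 in this assay, since each value is a limit: (the limit of > 10000 nM in this assay, at which 4 of the 4 values shown sit). The compounds shown leave open which change to the shared core, if any, would give a readable value in this assay at all.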